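The source may report more compounds than this note shows. Statements on the series, on what has been measured and on what is new or still open speak of the compounds shown alone.

Measured so far: compound 1 `NC(=O)Cn1c(=O)n(C2OC(CO)[C@@H](O)[C@H]2O)c2nc(N)nc(O)c21` gives 117 uM in a functional assay with Mus musculus as the target; a lower number here means that less compound is needed, a higher number that more compound is needed for the effect; compound 2 `Nc1nc(O)c2c(n1)n(C1OC(CO)[C@@H](O)[C@H]1O)c(=O)n2Cc1ccc([N+](=O)[O-])cc1` gives 50 uM in this assay.

Compound 2 stands with the lower of the two numbers, the step of a 2.3-fold lower number from compound 1 to compound 2 (0.37 log units; beyond the scatter) lying beyond the scatter. Compound 3 `CCCCn1c(=O)n(C2OC(CO)[C@@H](O)[C@H]2O)c2nc(N)nc(O)c21` differs from compound 2 in one place: propyl in place of 4-nitrophenyl on a saturated chain carbon bound to an aromatic nitrogen. For the measured compounds named here, no measured step exchanges these two groups; the single step of a 2.3-fold lower number from compound 1 to compound 2 (0.37 log units; beyond the scatter) changes a different group at the same place, so it bears only loosely. The expected step of a 1.4-fold higher number from compound 2 to compound 3 (0.15 log units; within the scatter) is therefore small and uncertain, likely within the scatter. Compound 3 is estimated at 70 uM, within 25 uM to 200 uM.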

Compound 3, concentration for half-maximal effect: 100 uM
The estimate for compound 3 lay 1.4-fold (0.15 log units) below the measured number; low and high end bracket the measured number.
By their numbers in this assay, from the lowest: compounds 2, 3 and 1 (each within the scatter of the next, the first and the last beyond it).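

In this assay the propyl group lands within the scatter on both sides, with a 2.0-fold higher number from compound 2 to compound 3 (0.30 log units; within the scatter) and a 1.2-fold lower number from compound 1 to compound 3 (0.07 log units; within the scatter). At this place on a saturated chain carbon bound to an aromatic nitrogen, a group with no ring and no hydrogen-bond acceptors therefore cannot be told apart from either the 4-nitrophenyl or the carbamoyl group, although those two are separated from each other. Nothing at hand explains this result. Still open, as far as these compounds go, is whether an amine, a carboxylic acid or a much longer chain at this place would move the number beyond the range these three compounds span.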